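The source may report more compounds than this note shows. Statements on the series, on what has been measured and on what is new or still open speak of the compounds shown alone.

In a functional assay on K562 cells (Homo sapiens) for antiproliferative activity, with a stated time of 72 h (a lower number here means a stronger inhibitor, a higher number a weaker inhibitor), compound 1 `CCCCC#Cc1cc([C@@H]2O[C@H](CO)[C@@H](O)[C@H]2O)n2ncnc(N)c12` gives 2400 nM and compound 2 `Nc1ncnn2c([C@@H]3O[C@H](CO)[C@@H](O)[C@H]3O)cc(C#CC3CC3)c12` gives 40 nM. Compound 3 `Nc1ncnn2c([C@@H]3O[C@H](CO)[C@@H](O)[C@H]3O)cc(C#Cc3ccccc3)c12` gives only a limit, > 100000 nM, and stands at the limit of > 100000 nM in this assay, at which 1 of the 3 values shown sits.

Compound 4 `Nc1ncnn2c([C@@H]3O[C@H](CO)[C@@H](O)[C@H]3O)cc(-c3ccc(F)cc3F)c12` carries 2,4-difluorophenyl in place of 2-phenylethynyl on an aromatic carbon, two ring bonds from the ring nitrogen: 2,4-difluorophenyl in place of 2-phenylethynyl on an aromatic carbon.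

Going by the values given here, three measured steps bear on this change, and all of them exchange the group on a triple-bonded carbon: a 60-fold lower number from compound 1 to compound 2 (1.78 log units; beyond the scatter), an at least 41-fold higher number from compound 1 to compound 3 (1.61 log units; beyond the scatter) and an at least 2500-fold higher number from compound 2 to compound 3 (3.39 log units; beyond the scatter). All three are large, so the number in this series can move far with a single change. None of them removes the triple bond, however, and none gives a direct size for this replacement. Starting from the limit of compound 3, a move to a lower number is expected, although compound 4 may also stay at that limit. The expected step is an at least 5.0-fold lower number from compound 3 to compound 4 (0.69 log units; beyond the scatter), and its size is uncertain. Compound 4 is estimated at 20000 nM, with an expected range of 1500 nM to 100000 nM.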

Compound 4, half-maximal inhibitory concentration: 69700 nM
The estimate for compound 4 lay 3.5-fold (0.54 log units) below the measured number, within the range that was stated.
By their numbers in this assay, from the lowest: compound 2; then compound 1; then compound 4. At a limit, above all of these: compound 3.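

Compound 3 is read only as a limit: the limit of > 100000 nM in this assay, at which 1 of the 4 values shown sits. In this assay, the change at this aromatic carbon gives an at least 1.4-fold lower number from compound 3 to compound 4 (0.15 log units; that floor lies within the scatter), so 2,4-difluorophenyl in place of 2-phenylethynyl is not resolved as an improvement, although compound 4 does give a number rather than a limit. Against the two compounds with the other triple-bonded groups, the directly attached 2,4-difluorophenyl stands far behind, with a 1700-fold higher number from compound 2 to compound 4 (3.24 log units; beyond the scatter) and a 29-fold higher number from compound 1 to compound 4 (1.46 log units; beyond the scatter).

It remains open whether the two fluorines matter, since the compounds shown do not separate them from the ring itself. Also open, going by these compounds, is whether a cyclopropyl group set directly on this carbon, or an amine at the end of a longer chain on the triple bond, would approach compound 2.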